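This account rests on a few compounds, and the source may have more. Where it says the series, first, only, none or still open, it means among the compounds named here.

In an ADME assay (liver) for metabolic stability, with Liver microsome (Rattus norvegicus) as the target, using microsomes and NADPH, with a stated time of 30 min, tested at 1 uM (a higher number here means faster removal of the compound, a lower number slower removal), compound 1 `Nc1ccc(S(=O)(=O)N2CCN(c3ncc(C(O)(C(F)(F)F)C(F)(F)F)cc3Br)CC2)cn1` gives 32 mL.min-1.g-1. Compound 2 `Nc1ccc(S(=O)(=O)N2CCN(c3ncc(C(O)(C(F)(F)F)C(F)(F)F)cc3C#CC3CC3)CC2)cn1` gives 67 mL.min-1.g-1 and compound 3 `Nc1ccc(S(=O)(=O)N2CCN(c3ncc(C(O)(C(F)(F)F)C(F)(F)F)cc3C#CCCO)CC2)cn1` gives 68 mL.min-1.g-1. Compound 3 therefore stands level with compound 2 within the scatter, and both lie above compound 1. The next structure, compound 4 `Nc1ccc(S(=O)(=O)N2CCN(c3ncc(C(O)(C(F)(F)F)C(F)(F)F)cc3-c3ccoc3)CC2)cn1`, has furan-3-yl in place of 4-hydroxybut-1-yn-1-yl on an aromatic carbon. Within the data shown here, three measured steps bear on this site. Putting 2-cyclopropylethynyl in place of bromo gave a 2.1-fold higher number from compound 1 to compound 2 (0.32 log units; beyond the scatter), and putting 4-hydroxybut-1-yn-1-yl in place of bromo gave a 2.1-fold higher number from compound 1 to compound 3 (0.33 log units; beyond the scatter), both modest. Swapping cyclopropyl for 2-hydroxyethyl on the triple-bonded carbon gave a 1.0-fold higher number from compound 2 to compound 3 (0.01 log units; within the scatter), within the scatter. Among the measured compounds shown here, no measured compound carries an aromatic ring at this site, so the guide is weak and the range must stay wide. The expected change is no step beyond the scatter: a 1.0-fold lower number from compound 3 to compound 4 (0.02 log units; within the scatter). Compound 4 is estimated at 65 mL.min-1.g-1, with an expected range from 32 mL.min-1.g-1 to 130 mL.min-1.g-1.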

Compound 4, intrinsic clearance in microsomes: 57 mL.min-1.g-1
Compound 4: the middle estimate sits 1.1-fold (0.06 log units) above what was measured; measured number inside the range.
By their numbers in this assay, from the lowest: compounds 1, 4, 2 and 3 (each within the scatter of the next, the first and the last beyond it).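

In this assay, the first aromatic ring at this position, furan-3-yl, stands level with both alkynes (a 1.2-fold lower number from compound 3 to compound 4 (0.08 log units; within the scatter); a 1.2-fold lower number from compound 2 to compound 4 (0.07 log units; within the scatter)), so this site tolerates losing the triple bond, and, relative to compound 3, the hydrogen-bond donor, with no change beyond the scatter. Set against the bromo compound, the furan gives a step that stays within the scatter (a 1.8-fold higher number from compound 1 to compound 4 (0.25 log units; within the scatter)), whereas both alkyne steps from compound 1 lie just beyond it, so the four compounds span only a narrow range. Nothing measured here explains these numbers. Going by these compounds, it remains open whether a larger aromatic ring such as phenyl, or an amine or a carboxylic acid at this position, would move the number clearly away from this range. On these data alone, it is also open whether any group here could bring it lower than the value of compound 1 (32 mL.min-1.g-1).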